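This account rests on a few compounds, and the source may have more. Where it says the series, first, only, none or still open, it means among the compounds named here.

Among the compounds with values here, compound 1 `CC1(C)Oc2ccc(C#N)cc2[C@@H](/N=C(\NC#N)Nc2ccc(Cl)cc2)[C@@H]1O` is one of three compounds measured in a functional assay (aorta) with Rattus norvegicus as the target; a higher number here means a weaker inhibitor, a lower number a stronger inhibitor. There compound 1 gives 1800 nM, the second highest of the three numbers. Compound 3 `CC1(C)Oc2ccc(C#N)cc2[C@@H](NC(=O)Nc2ccncc2)[C@@H]1O` sits higher with 8500 nM, and compound 2 `C/N=C(\NC#N)N[C@@H]1c2cc(C#N)ccc2OC(C)(C)[C@H]1O` sits lower with 200 nM; both gaps to compound 1 lie beyond the usual scatter. Compound 4 `CC1(C)Oc2ccc(C#N)cc2[C@@H](/N=C(\NC#N)Nc2cccc(C(=O)O)c2)[C@@H]1O` has not yet been measured. It differs from compound 1 in one place: 3-carboxyphenyl in place of 4-chlorophenyl on an amine nitrogen. Within the data shown here, no measured pair shows this exchange, so any expectation rests only on the three values given here and on the change itself. In this assay a modest step towards a weaker inhibitor is expected, a 2.2-fold higher number from compound 1 to compound 4 (0.35 log units; beyond the scatter). Compound 4 is therefore estimated at 4000 nM, with a range from 1000 nM to 15000 nM.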

Compound 4, half-maximal inhibitory concentration: > 100000 nM
Compound 4 gave a limit, no number (the forecaster's own chance of this, stated with the estimate: 10%); middle value at least 25-fold (1.39 log units) from the limit.
By their numbers in this assay, from the lowest: compound 2; then compound 1; then compound 3. At a limit, above all of these: compound 4.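

In this assay, compound 4 gives only a limit, not a number: the limit of > 100000 nM in this assay, at which 1 of the 4 values shown sits.

Placing 3-carboxyphenyl in place of 4-chlorophenyl on this amine nitrogen gives an at least 55-fold higher number from compound 1 to compound 4 (1.74 log units; beyond the scatter), so keeping an aromatic ring here does not by itself preserve activity. Within the data shown here, this is the first one-place step available, and it shows that the group at this position can decide whether a compound registers at all.

Open, as far as these compounds go, is whether the loss follows from the carboxylic acid itself or from where it sits on the ring. A 4-carboxyphenyl or a 3-chlorophenyl group on this nitrogen would separate the two.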